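From a bromophenyl ketone to a cyclopropyl ketone

The compounds below may be only part of what the source reports. "The series", "measured", "known", "first", "only" and "open" are said of these compounds alone.

Compound 1 `COc1cc(-c2nnc3n2NC(c2ccco2)C(C(=O)c2ccccc2C)S3)cc(OC)c1OC` gives 63000 nM in a functional assay on HepG2 cells (Homo sapiens) for cytotoxicity, read by MTT assay, with a stated time of 48 h; on this read-out higher numbers stand for weaker inhibition and lower numbers for stronger inhibition.
Compound 2 `COc1cc(-c2nnc3n2NC(c2ccco2)C(C(=O)c2ccc(Br)cc2)S3)cc(OC)c1OC` reaches only the limit > 100000 nM in this assay.
Compound 3 `COc1cc(-c2nnc3n2NC(c2cccs2)C(C(=O)c2ccc(C)cc2)S3)cc(OC)c1OC` gives 3700 nM in this assay.

Compound 2 stands at a limit of this assay, not a number, the line (the limit of > 100000 nM in this assay, at which 1 of the 3 values shown sits). Compound 4 `COc1cc(-c2nnc3n2NC(c2ccco2)C(C(=O)C2CC2)S3)cc(OC)c1OC` differs from compound 2 by cyclopropyl in place of 4-bromophenyl on a carbonyl carbon. Going by the values given here, the only measured step touching this carbonyl is an at least 1.5-fold higher number from compound 1 to compound 2 (0.20 log units; that floor lies within the scatter), and it ends at the limit, so it sets no scale for the cyclopropyl change. Compound 3 carries a different ring at the saturated ring carbon as well, so its value says nothing directly about compound 4. Among the compounds with values here, with no precedent, compound 4 is expected to stay weak, the step of an at least 1.4-fold lower number from compound 2 to compound 4 (0.15 log units; that floor lies within the scatter) being the estimate. Compound 4 is estimated at 70000 nM, between 15000 nM and 300000 nM.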

Compound 4, half-maximal inhibitory concentration: > 100000 nM
Compound 4 gave a limit, no number (the forecaster's own chance of this, stated with the estimate: 45%); at least 1.4-fold (0.15 log units) between middle value and limit.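

Compound 4 joins compound 2 at a limit of this assay, not at a number: the limit of > 100000 nM in this assay, at which 2 of the 4 values shown sit.

The step between these two compounds cannot be read, so the change from 4-bromophenyl to cyclopropyl on this carbonyl carbon has no size here. Measured from compound 1, cyclopropyl in place of 2-methylphenyl gives an at least 1.5-fold higher number from compound 1 to compound 4 (0.20 log units; that floor lies within the scatter), so a non-aromatic ring on this carbonyl carbon also ends at the limit.

On these data alone, whether an amine or a longer chain on this carbonyl carbon would give a number in this assay stays open.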